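The source may report more compounds than this note shows. Statements on the series, on what has been measured and on what is new or still open speak of the compounds shown alone.

Of the compounds shown here, two built on the shared core have been measured so far in an ADME assay on Caco-2 cells (Homo sapiens) for permeability, tested at 50 uM; a higher number here means that the compound crosses the layer faster, a lower number that the compound crosses the layer more slowly. Compound 1 `CCN(CC)CCN1CCN(C(=O)COCCN(C)S(=O)(=O)c2c(C)cc(OC)cc2C)CC1` gives 0.9 10^-6 cm/s, and compound 2 `COc1cc(C)c(S(=O)(=O)N(C)CCOCC(=O)N2CCN(CC3CCN(C)CC3)CC2)c(C)c1` gives 1.5 10^-6 cm/s. Among the compounds with values here, these two values lie within the scatter of each other, so compound 2 does not stand apart from the only other number available. The next structure is compound 3 `CCN1CCC(N2CCN(C(=O)COCCN(C)S(=O)(=O)c3c(C)cc(OC)cc3C)CC2)CC1`, which has the same atoms as compound 2, joined differently. The change is 1-ethylpiperidin-4-yl in place of (1-methylpiperidin-4-yl)methyl on an amine nitrogen in a ring. In words, 1-ethylpiperidin-4-yl takes the place of (1-methylpiperidin-4-yl)methyl on an amine nitrogen in a ring. Within the data shown here, only one measured step bears on this: a 1.7-fold higher number from compound 1 to compound 2 (0.22 log units; within the scatter). That step also alters the group carried on an amine nitrogen in a ring, and it did not leave the scatter. Among the measured compounds shown here, no measured compound yet shows the effect of this exact exchange, so no shift beyond the scatter is expected in this assay. The expected change is a 1.3-fold lower number from compound 2 to compound 3 (0.10 log units; within the scatter). Compound 3 is estimated at 1.2 10^-6 cm/s, with an expected range from 0.5 10^-6 cm/s to 2.8 10^-6 cm/s.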

Compound 3, apparent permeability: 1.7 10^-6 cm/s
Compound 3: the middle estimate sits 1.4-fold (0.15 log units) below what was measured, and the stated range covers the measured number.
By their numbers in this assay, from the lowest: compounds 1, 2 and 3 (each within the scatter of the next).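

In this assay, within the data shown here, 1-ethylpiperidin-4-yl in place of (1-methylpiperidin-4-yl)methyl on an amine nitrogen in a ring gives a 1.1-fold higher number from compound 2 to compound 3 (0.05 log units; within the scatter), the first direct reading of this exact exchange, and it shows that rejoining the same atoms at this place stays within the scatter. The wider exchange at the same place, 1-ethylpiperidin-4-yl in place of 2-(diethylamino)ethyl, gives a 1.9-fold higher number from compound 1 to compound 3 (0.28 log units; within the scatter), so the open-chain group and the two groups that carry a six-membered non-aromatic ring all lie within the scatter of one another. Nothing available here offers an explanation for these numbers.

As far as these compounds go, all three groups at this place carry a further amine, so it remains open whether a group without one, such as a cyclohexyl or a phenyl ring, would leave the scatter. From the compounds shown here alone, the rest of the shared core is the same in all three compounds, and what a change there would do, such as a carboxylic acid in place of the methoxy group, also stays open.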